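Ring substituent change in a fused amide series

A few compounds are considered here, and "the series" means these few. Any claim that something is new, unique, unknown or untested is made for them only; others in the source may bear on it.

Measured so far:
compound 1 `CC(=O)Nc1nc(-c2ccccc2)nc2nc(C)cn12`: 231 nM
compound 2 `CC(=O)CNc1nc(-c2ccccc2)nc2nc(C)cn12`: limit, > 10000 nM
compound 3 `CC(C)c1cn2c(NC(=O)C3CCCC3)nc(-c3ccccc3)nc2n1`: 17.4 nM

In an assay on cell membranes for displacement of a labelled ligand from adenosine receptor A3 (Homo sapiens), in the presence of a further agent that is not named here (a lower number here means a stronger inhibitor, a higher number a weaker inhibitor), compound 1 gives 231 nM. Compound 2 reaches only a limit of the assay, > 10000 nM. Compound 3 gives 17.4 nM, the lowest of the two numbers, with compound 1 the nearest. Within the data shown here, the one measured step, an at least 43-fold higher number from compound 1 to compound 2 (1.63 log units; beyond the scatter), concerns the group on the amide nitrogen and is only a lower bound since one value sits at the limit of > 10000 nM in this assay, at which 1 of the 3 values shown sits.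

Compound 4 `O=C(Nc1nc(-c2ccccc2)nc2nc(-c3ccccc3)cn12)C1CCCC1` differs from compound 3 by phenyl in place of isopropyl on an aromatic carbon. Among the measured compounds shown here, no measured step touches this position, so no change beyond the scatter is expected in this assay. Compound 4 is expected at 30 nM (range 8 nM to 120 nM), a step of a 1.7-fold higher number from compound 3 to compound 4 (0.24 log units; within the scatter).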

Compound 4, inhibition constant: 1240 nM
The estimate for compound 4 lay 41-fold (1.62 log units) below the measured number, and the stated range ends below it.
By their numbers in this assay, from the lowest: compound 3; then compound 1; then compound 4. At a limit, above all of these: compound 2.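

In this assay, phenyl in place of isopropyl on this aromatic carbon brings a 71-fold higher number from compound 3 to compound 4 (1.85 log units; beyond the scatter) with the amide group unchanged. The position, which the earlier step did not touch, is therefore far from indifferent to the group it carries. Nothing shown gives a reason for this step.

Open, going by these compounds, is whether cyclohexyl, a saturated ring of the same ring size as phenyl, or a primary amine on this carbon would stay near compound 3 or fall toward compound 4. Also open, on these data alone, is whether the step holds with acetyl on the amide nitrogen.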